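Fluoro in place of amino on compound 2

The source may report more compounds than this note shows. Statements on the series, on what has been measured and on what is new or still open speak of the compounds shown alone.

In a functional assay on KBVIN cells (Homo sapiens) for antiproliferative activity, read by sulforhodamine B assay, with a stated time of 48 h (a higher number here means a weaker inhibitor of growth, a lower number a stronger inhibitor of growth), compound 1 (`N#Cc1ccc(Nc2nc(NCCCO)c3ccccc3n2)cc1`) gives 4310 nM and compound 2 (`Nc1ccc(Nc2nc(NCCCO)c3ccccc3n2)cc1`) gives 18700 nM as the higher of the two numbers. Compound 3 (`OCCCNc1nc(Nc2ccc(F)cc2)nc2ccccc12`) differs from compound 2 by fluoro in place of amino on an aromatic carbon with fluoro in place of amino on an aromatic carbon. Among the compounds with values here, the only measured step at this place is a 4.3-fold higher number from compound 1 to compound 2 (0.64 log units; beyond the scatter) and it lies beyond the scatter, with amino in place of cyano. A step of modest size toward a lower number is therefore expected, and the expected step is a 2.3-fold lower number from compound 2 to compound 3 (0.37 log units; beyond the scatter) in this assay for this change. Compound 3 is estimated at 8000 nM with an expected range from 3000 nM to 20000 nM in this measurement.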

Compound 3, concentration for 50% growth inhibition: 24200 nM
Compound 3: the middle estimate sits 3.0-fold (0.48 log units) below what was measured; the whole stated range lies below it.
By their numbers in this assay, from the lowest: compound 1; then compounds 2 and 3 (each within the scatter of the next).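

In this assay fluoro in place of amino gives a 1.3-fold higher number from compound 2 to compound 3 (0.11 log units; within the scatter) and so the two groups are not separated at this position, though amino counts a hydrogen-bond donor and acceptor and fluoro neither. Fluoro in place of cyano gives a 5.6-fold higher number from compound 1 to compound 3 (0.75 log units; beyond the scatter) and so, of these three groups, only cyano stands apart here. Nothing available explains this result.

Going by these compounds, whether a carboxylic acid or a methoxy group here would stand with cyano or with amino and fluoro remains open. So does whether cyano keeps its place with a longer chain on the shared core.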